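This account rests on a few compounds, and the source may have more. Where it says the series, first, only, none or still open, it means among the compounds named here.

Compound 1 `O=C1C(N2CCCC2)=CC(=O)c2c1nc1n2[C@H]2OC[C@@H](O)[C@H]2OC1` gives > 16000 nM in a functional assay on HeLa cells (Homo sapiens) for inhibition, read by sulforhodamine B assay (on this read-out lower numbers stand for stronger inhibition and higher numbers for weaker inhibition), which is a limit of the assay.
Compound 2 `O=C1C(N2CCCCC2)=CC(=O)c2c1nc1n2[C@H]2OC[C@@H](O)[C@H]2OC1` gives > 16000 nM in this assay, again a limit.
Compound 3 `CCOc1ccccc1NC1=CC(=O)c2nc3n(c2C1=O)[C@H]1OC[C@@H](O)[C@H]1OC3` gives 6040 nM in this assay.

Compound 2 thus stands at the limit of > 16000 nM in this assay, at which 2 of the 3 values shown sit, and only that limit is known for it. Compound 4 `O=C1C(NC2CCCCC2)=CC(=O)c2c1nc1n2[C@H]2OC[C@@H](O)[C@H]2OC1` differs from compound 2 by cyclohexylamino in place of piperidin-1-yl on a double-bonded ring carbon. Going by the values given here, the single measured step, a step that the two limits leave unreadable from compound 1 to compound 2, has a limit at both ends and offers no size. Among the compounds with values here, compound 3, the one compound with a number, also carries an amine with a hydrogen-bond donor, so a step toward stronger inhibition is expected for compound 4, of about an at least 1.6-fold lower number from compound 2 to compound 4 (0.20 log units; that floor lies within the scatter), though a further limit remains quite possible. Compound 4 is estimated at 10000 nM, between 3000 nM and 30000 nM.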

Compound 4, half-maximal inhibitory concentration: > 16000 nM
Compound 4: only a limit was reported (the forecaster's own chance of this, stated with the estimate: 45%); middle value at least 1.6-fold (0.20 log units) from the limit.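

Compound 1, compound 2 and compound 4 all sit at the same limit, so no step among them can be read: the limit of > 16000 nM in this assay, at which 3 of the 4 values shown sit.

As far as these compounds go, whether cyclohexylamino in place of piperidin-1-yl changes inhibition at all stays open.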